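Positional isomer of the methyltriazole in a weak hydrazone urea

This account rests on a few compounds, and the source may have more. Where it says the series, first, only, none or still open, it means among the compounds named here.

Compound 1 `COc1ccc(OC)c(/C=N/NC(=O)Nc2ccc(Oc3ccnc(-c4nncn4CCN(C)C)c3)c(F)c2)c1`: 2070 nM
Compound 2 `CN(C)CCn1cnnc1-c1cc(Oc2ccc(NC(=O)N/N=C/c3ccc(O)c(Br)c3)cc2F)ccn1`: 450 nM
Compound 3 `Cn1ncnc1-c1cc(Oc2ccc(NC(=O)N/N=C/c3ccccc3)cc2F)ccn1`: 30200 nM

In a functional assay on HT-29 cells (Homo sapiens) for cytotoxicity, read by MTT assay, with a stated time of 72 h (on this read-out lower numbers stand for stronger inhibition and higher numbers for weaker inhibition), compound 3 gives the highest number of the three measured compounds, with compound 1 standing well below it and compound 2 further still. Among the measured compounds shown here, the one measured step, a 4.6-fold lower number from compound 1 to compound 2 (0.66 log units; beyond the scatter), concerns the aryl group on the hydrazone and says nothing about the heterocycle. Compound 4 `Cn1cnnc1-c1cc(Oc2ccc(NC(=O)N/N=C/c3ccccc3)cc2F)ccn1` differs from compound 3 only by 4-methyl-4H-1,2,4-triazol-3-yl in place of 1-methyl-1H-1,2,4-triazol-5-yl on an aromatic carbon. For the measured compounds named here, no measured pair in this assay touches that part of the molecule, so the data give no direction for the step. Compound 4 is therefore expected to sit close to compound 3, with a step of a 1.1-fold lower number from compound 3 to compound 4 (0.03 log units; within the scatter) that lies within the scatter. The estimate for compound 4 in this assay is 28000 nM, between 9000 nM and 90000 nM.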

Compound 4, half-maximal inhibitory concentration: 8790 nM
Estimate against measurement, compound 4: 3.2-fold (0.50 log units) above, outside the stated range (below it).
By their numbers in this assay, from the lowest: compound 2; then compound 1; then compound 4; then compound 3.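

In this assay, the triazole attached next to the ring nitrogen proves sensitive to how its atoms are joined: 4-methyl-4H-1,2,4-triazol-3-yl in place of 1-methyl-1H-1,2,4-triazol-5-yl gives a 3.4-fold lower number from compound 3 to compound 4 (0.54 log units; beyond the scatter), although both groups have the same atoms and the same donor and acceptor counts. The earlier compounds shown here showed change only at the hydrazone aryl group. Nothing available accounts for the difference between the two isomers.

On these data alone, it remains open whether this preference between isomers carries over to compounds with a substituted hydrazone aryl group. Also open, as far as these compounds go, is how a propyl or cyclopropyl group would fare in place of the methyl on the triazole of compound 4.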